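This account rests on a few compounds, and the source may have more. Where it says the series, first, only, none or still open, it means among the compounds named here.

Measured compounds:
- compound 1, `Oc1ccccc1CNc1ccc(N2CCNCC2)cc1` — in a functional assay on Jurkat cells (Homo sapiens) for activation, with a stated time of 24 h (a lower number here means that less compound is needed, a higher number that more compound is needed for the effect), compound 1 gives "not active" (no number reported)
- compound 2, `Oc1ccccc1CNc1ccc(-c2cccc(F)c2)cc1` — in this assay compound 2 gives 2020 nM

Among the measured compounds shown here, compound 2 stands as the only compound of the series with a number in this assay; the other entry, compound 1, carries no number, so no step between measured compounds can be drawn. For the measured compounds named here, the two structures share the hydroxybenzylamino-phenyl part and differ in what sits on the far aromatic carbon, but with no number for compound 1 the pair shows only that compound 2 is active while compound 1 is reported as not.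

Compound 3, `CCOc1cccc(-c2ccc(NCc3ccccc3O)cc2)c1`, is the next compound for this assay. It differs from compound 2 by ethoxy in place of fluoro on an aromatic carbon, meta to a large group. With only one numbered anchor, nothing in the series shows how this position responds to a change of group. The expectation for this assay is therefore a step of no clear direction, and none beyond the usual scatter: a change by a 1.1-fold lower number from compound 2 to compound 3 (0.05 log units; within the scatter) is estimated. On that basis compound 3 is expected to give about 1800 nM in this assay, within a range of 600 nM to 5500 nM.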

Compound 3, half-maximal effective concentration: "not active" (no number reported)
The entry for compound 3 holds no number, and the estimate cannot be compared.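

In this assay, among the compounds shown here, compound 3 carries no number, so no step from compound 2 to compound 3 can be read. No evidence bears on this result. The compounds shown leave open how this assay responds to changes of group at this aromatic carbon, as compound 2 remains the only compound with a number.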